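The compounds below may be only part of what the source reports. "The series", "measured", "known", "first", "only" and "open" are said of these compounds alone.

Compound 1 `COc1ccc(/C=C/C(=O)OCC2CCN(Cc3ccccc3)CC2)cc1O`: > 100000 nM
Compound 2 `COc1ccc(/C=C/C(=O)OCC2CCN(Cc3ccc(Br)cc3)CC2)cc1O`: > 100000 nM

Both compounds were tested in a functional assay, with a stated time of 30 min; a higher number here means that more compound is needed for the effect, a lower number that less compound is needed. In this assay compound 1 gives > 100000 nM, which is a limit of the assay and not a number. Compound 2 gives > 100000 nM, and this too is only a limit. Compound 2 therefore stands at the limit of > 100000 nM in this assay, at which 2 of the 2 values shown sit, with no measured number to place it more exactly.

The next structure, compound 3 `COc1ccc(/C=C/C(=O)OCC2CCN(Cc3ccc(Cl)cc3)CC2)cc1O`, keeps the core of compound 2 and has chloro in place of bromo on an aromatic carbon, para to a large group: chloro in place of bromo on an aromatic carbon.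

Among the compounds with values here, only one measured step bears on this change, and it also concerns that aromatic carbon: a step that the two limits leave unreadable from compound 1 to compound 2. It brought bromo in place of hydrogen, but it provides no size to carry over. No step beyond the usual scatter is therefore expected in this assay, and no direction can be assigned.

The estimate must start from compound 2 at > 100000 nM, which is a limit. The estimated change is a number no higher from compound 2 to compound 3 (the limit leaves the size open). Most likely the assay will again report only a limit. For compound 3 the expected value is 100000 nM, with an estimated range of 40000 nM to 250000 nM.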

Compound 3, half-maximal effective concentration: 12500 nM
Compound 3: middle estimate off by 8.0-fold (0.90 log units), on the high side; the measured number lies below the stated range.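

In this assay the group on this aromatic carbon does matter, since chloro in place of bromo gives an at least 8.0-fold lower number from compound 2 to compound 3 (0.90 log units; beyond the scatter) and so provides the first readable change among these compounds. Chloro also differs from hydrogen at the same carbon, with an at least 8.0-fold lower number from compound 1 to compound 3 (0.90 log units; beyond the scatter) as the step, so the two halogens do not behave alike here: bromo leaves the compound at a limit as hydrogen does, while chloro brings a measured number. Compound 3 is the only one of the three with such a number, and compound 1 and compound 2 each remain at a limit, so both steps give only a smallest size and their true size stays open: the limit of > 100000 nM in this assay, at which 2 of the 3 values shown sit.

The compounds shown leave open whether this drop belongs to chloro alone or would also appear with other groups on that carbon, such as fluoro, methyl or methoxy. They also leave open whether the 4-chlorobenzyl group would give a measured number on a core that carries an amide in place of the ester.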